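Nitroimidazole Amide Replacing Nitrophenyl on the Shared Core

The source may report more compounds than this note shows. Statements on the series, on what has been measured and on what is new or still open speak of the compounds shown alone.

Of the compounds shown here, three on the shared core have been tested in an assay on CHO-K1 cells for activation of DNA damage-inducible transcript 3 protein (Homo sapiens), read by a luciferase reporter; a lower number here means that less compound is needed, a higher number that more compound is needed for the effect. Compound 1 `O=C(Nc1ccc(S(=O)(=O)N2CCNCC2)cc1)c1ccc([N+](=O)[O-])o1` gives 26400 nM. Compound 2 `CC1(C)CCN(S(=O)(=O)c2ccc(NC(=O)c3ccc([N+](=O)[O-])o3)cc2)CC1` gives 600 nM, which amounts to a 44-fold lower number from compound 1 to compound 2 (1.64 log units; beyond the scatter). For compound 3 `CC1(C)CCN(S(=O)(=O)c2ccc(NC(=O)c3cccc([N+](=O)[O-])c3)cc2)CC1` only a limit of the assay is known, > 80000 nM. Compound 3 thus sits at the limit of > 80000 nM in this assay, at which 1 of the 3 values shown sits, and is the only one of the three to do so; the step that led there, an at least 130-fold higher number from compound 2 to compound 3 (2.12 log units; beyond the scatter), was large and beyond the scatter.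

Compound 4 `Cn1c([N+](=O)[O-])cnc1C(=O)Nc1ccc(S(=O)(=O)N2CCC(C)(C)CC2)cc1` differs from compound 3 in one place: 1-methyl-5-nitro-1H-imidazol-2-yl in place of 3-nitrophenyl on a carbonyl carbon. For the measured compounds named here, the measured step that bears on this is the one from compound 2 to compound 3, in which a five-membered aromatic ring carrying a nitro group gave way to a six-membered carbon ring and the number rose by a large amount. Compound 4 brings back a five-membered aromatic ring bearing a nitro group, so a large step downward in this assay is expected, though it need not reach the value of compound 2. Compound 4 is therefore estimated at 2000 nM, within 300 nM to 20000 nM, which is expected to mean an at least 40-fold lower number from compound 3 to compound 4 (1.60 log units; beyond the scatter).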

Compound 4, concentration for half-maximal activity: > 80000 nM
Compound 4 was reported as a limit (the forecaster's own chance of this, stated with the estimate: 15%); at least 40-fold (1.60 log units) between middle value and limit.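

In this assay the change gave an at least 130-fold higher number from compound 2 to compound 4 (2.12 log units; beyond the scatter), so a five-membered aromatic ring bearing a nitro group does not by itself preserve the activity seen with 5-nitrofuran-2-yl on a carbonyl carbon whose other neighbour is an amide-type nitrogen. The step from compound 3 cannot be read, as both compound 3 and compound 4 stand at a limit of the assay, so 3-nitrophenyl and 1-methyl-5-nitro-1H-imidazol-2-yl cannot be ranked against each other. Of the three groups shown at this place, only 5-nitrofuran-2-yl gives a value short of that limit: the limit of > 80000 nM in this assay, at which 2 of the 4 values shown sit.

The compounds shown leave open whether the nitro group is needed on the furan, which a plain furan-2-yl group would test, and whether a 5-nitrothiophen-2-yl group would keep a value close to that of compound 2, 600 nM. Also open, on these data alone, is whether the methyl group on the imidazole matters, which a 5-nitro-1H-imidazol-2-yl group with a hydrogen in place of that methyl would address.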